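This account rests on a few compounds, and the source may have more. Where it says the series, first, only, none or still open, it means among the compounds named here.

Measured so far:
compound 1 `Oc1ccc(-c2cc(-c3ccccc3O)cc(-c3cccc(O)c3)n2)cc1` – 0%
compound 2 `Oc1cccc(-c2cc(-c3ccccc3O)cc(-c3cccc(O)c3)n2)c1` – 0%

In an assay on isolated protein for inhibition of DNA topoisomerase 1 (Homo sapiens), with a stated time of 30 min, tested at 100 uM (a higher number here means more inhibition at the concentration tested (going by the name of the read-out), a lower number less inhibition), compound 1 gives 0%, level with compound 2 at the digits printed; the step of no change at the digits printed from compound 1 to compound 2 (within the scatter) lies within the scatter. Compound 3 `Oc1ccc(-c2cc(-c3cccc(O)c3)cc(-c3cccc(O)c3)n2)cc1` is not yet measured. It differs from compound 1 by 3-hydroxyphenyl in place of 2-hydroxyphenyl on an aromatic carbon. Going by the values given here, the only step that bears on this change is the one from compound 1 to compound 2, which showed no change beyond the scatter when one hydroxyphenyl was exchanged for another. For compound 3 a step of no change at the digits printed from compound 1 to compound 3 (within the scatter) is therefore expected, none beyond the scatter. Compound 3 is estimated at 0%, between 0% and 10%.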

Compound 3, a percentage reported as inhibition, at one concentration (the size of the read-out at that concentration, not a potency): 0%
Compound 3: the middle estimate sits on the measured number at the digits printed; the measured number falls inside the stated range.
By their numbers in this assay, from the lowest: compounds 1, 2 and 3 (each within the scatter of the next).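

In this assay, the exchange of 2-hydroxyphenyl for 3-hydroxyphenyl on the carbon opposite the ring nitrogen gives no change at the digits printed from compound 1 to compound 3 (within the scatter) at this concentration. The earlier step concerned a different place on the core, so this is the only reading shown for this position. Nothing measured here bears on why the reading stays flat.

With compound 3 at 0%, no compound shown gives a reading from which a gain or loss could be seen. Going by these compounds, whether an amine or a carboxylic acid at this position would give any inhibition remains open.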